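A few compounds are considered here, and "the series" means these few. Any claim that something is new, unique, unknown or untested is made for them only; others in the source may bear on it.

Measured compounds:
compound 1, `C[C@H](NC(=O)CN(c1nc(Cl)nc2[nH]cnc12)C1CC1)C(=O)OCc1ccccc1`, 64.3%
compound 2, `O=C(O)[C@@H]1CCCN1C(=O)CN(c1nc(Cl)nc2[nH]cnc12)C1CC1`, 34.9%
compound 3, `CC[C@H](C)[C@H](NC(=O)CN(c1ncnc2c1ncn2C1CCCCO1)C1CC1)C(=O)OCc1ccccc1`, 27.4%

In a functional assay on the whole organism (Tail, strain ICR) with Mus musculus as the target, in the tail flick test, with a stated time of 60 min, at a dose of 25 umol/kg by the oral route (a lower number here means a weaker effect, a higher number a stronger effect of the compound at the dose given), compound 1 gives the highest of the three numbers. Compound 2 gives 34.9%, a number beyond the scatter below it, and compound 3 gives 27.4%, further below still. These three compounds differ from one another in more than one place, so their values show only where each stands and no single step can be read from them.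

Compound 4, `O=C(CN(c1nc(Cl)nc2[nH]cnc12)C1CC1)N[C@@H](CCC(=O)OCc1ccccc1)C(=O)OCc1ccccc1`, has not yet been measured. It differs from compound 1 in one place: (benzyloxycarbonyl)methyl in place of hydrogen on a saturated chain carbon, two bonds along the chain from an amide-type nitrogen and a carbonyl carbon. Going by the values given here, no pair of measured compounds shows this kind of change, so the size of the step from compound 1 to compound 4 cannot be read from the data. Compound 2 and compound 3, which carry other groups at a similar part of the molecule, both stand below compound 1. On that basis a step downward is expected, beyond the scatter but not to the level of compound 3. Compound 4 is expected to give about 45%, within a range from 20% to 70%, which means an expected step of a number 19.3 percentage points lower from compound 1 to compound 4 (beyond the scatter).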

Compound 4, a percentage reported as activity, at one dose (the size of the read-out at that dose, not a potency): 53.7%
Estimate against measurement, compound 4: 8.7 percentage points below; low and high end bracket the measured number.
By their numbers in this assay, from the lowest: compounds 3 and 2 (each within the scatter of the next); then compound 4; then compound 1.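

Going by these compounds alone, putting (benzyloxycarbonyl)methyl in place of hydrogen on a saturated chain carbon, two bonds along the chain from an amide-type nitrogen and a carbonyl carbon, gives a number 10.6 percentage points lower from compound 1 to compound 4 (beyond the scatter) in this assay and is the first change in one place that can be read. It shows that this chain carbon can carry a much larger group, seen also as methyl to 2-(benzyloxycarbonyl)ethyl, with a modest loss and with compound 4 keeping 53.7% at the dose given. No data at hand account for the step.

On these data alone, it remains open whether the loss follows from the longer chain or from its benzyl ester, which a free carboxylic acid or an amine at the end of the same chain would help to separate. A single dose and time also leave open whether the step would hold at other doses or times.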